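This account rests on a few compounds, and the source may have more. Where it says the series, first, only, none or still open, it means among the compounds named here.

Compound 1, with the structure `Clc1ccc(-c2ccnc3c2c(-c2ccccc2)nn3-c2ccccc2)cc1`, is the starting point of this small set. In a functional assay on MCF7 cells (Homo sapiens) for inhibition, read by MTT assay, with a stated time of 48 h (on this read-out lower numbers stand for stronger inhibition and higher numbers for weaker inhibition), compound 1 gives 61100 nM. Compound 2, `Cc1ccc(-c2ccnc3c2c(-c2ccccc2)nn3-c2ccccc2)cc1`, differs from it in one place: the change (methyl in place of chloro on an aromatic carbon). In this assay compound 2 gives 5590 nM, and the step of an 11-fold lower number from compound 1 to compound 2 (1.04 log units; beyond the scatter) is therefore large.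

Compound 3 has the structure `O=C(C=CNc1cc(-c2ccccc2)nn1-c1ccccc1)c1ccc(Cl)cc1` and is built on a different core; how its core differs from that of compound 1 is not broken down here. In this assay compound 3 gives 8070 nM, so its value and that of compound 2 lie within the usual scatter of each other, while it stands well apart from compound 1.

Compound 4, `Cc1ccc(C(=O)C=CNc2cc(-c3ccccc3)nn2-c2ccccc2)cc1`, is not yet measured. It carries the change (methyl in place of chloro on an aromatic carbon), the same change that turns compound 1 into compound 2, now placed on the core of compound 3. Whether the large step seen on the first core carries over to this core is the open question. For the measured compounds named here, the one earlier step, an 11-fold lower number from compound 1 to compound 2 (1.04 log units; beyond the scatter), points toward a lower number, but a single example on a different core is a thin basis, so a smaller step is expected here: for compound 4 the estimated step is a 3.0-fold lower number from compound 3 to compound 4 (0.48 log units; beyond the scatter). Compound 4 is thus expected to give about 2700 nM in this assay, most likely between 900 nM and 9000 nM.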

Compound 4, half-maximal inhibitory concentration: 30200 nM
Estimate against measurement, compound 4: 11-fold (1.05 log units) below; measured number outside the range, above it.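

On the second core, swapping 4-chlorophenyl for 4-methylphenyl gives a 3.7-fold higher number from compound 3 to compound 4 (0.57 log units; beyond the scatter) in this assay, so the number moves the opposite way to the step seen on the first core. The effect of this change therefore does not carry from one core to the other here, neither in direction nor in size, and a result from one core would have been a poor guide to the other: the same change on two cores in this assay, an 11-fold lower number (1.04 log units; beyond the scatter) from compound 1 to compound 2 and a 3.7-fold higher number (0.57 log units; beyond the scatter) from compound 3 to compound 4, 41-fold (1.61 log units) apart, beyond the scatter of two such steps
For the compounds shown here, this does not show why the two cores respond differently, and with only one pair on each core, it gives no rule for the series as a whole; it shows only that these two pairs disagree.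

The compounds shown leave open how each core responds to other groups in the same place on the ring, since only chloro and methyl appear there, and a fluoro, a methoxy or an amine group could show whether the two cores keep moving in opposite directions. They also leave open whether a longer chain, such as ethyl or propyl, in place of the methyl would follow the methyl on each core.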